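The source may report more compounds than this note shows. Statements on the series, on what has been measured and on what is new or still open speak of the compounds shown alone.

Within the data shown here, in a functional assay on the whole organism (Tail, strain ICR) with Mus musculus as the target, in the tail flick test, with a stated time of 120 min, at a dose of 25 umol/kg by the oral route (on this read-out higher numbers stand for a stronger effect at the one dose given and lower numbers for a weaker effect), compound 1 `C[C@@H](O)[C@H](NC(=O)CN(c1ncnc2c1ncn2C1CCCCO1)C1CC1)C(=O)OCc1ccccc1` gives 10.9% and compound 2 `O=C(CN(c1ncnc2c1ncn2C1CCCCO1)C1CC1)N[C@@H](CC(=O)OCc1ccccc1)C(=O)OCc1ccccc1` gives 7.82%; compound 2 stands lowest of the two numbers, separated from its only neighbour by a number 3.1 percentage points lower from compound 1 to compound 2 (within the scatter). Compound 3 `CC(C)C[C@H](NC(=O)CN(c1ncnc2c1ncn2C1CCCCO1)C1CC1)C(=O)OCc1ccccc1` differs from compound 2 by isopropyl in place of benzyloxycarbonyl on a saturated chain carbon, two bonds along the chain from an amide-type nitrogen and a carbonyl carbon. Among the measured compounds shown here, the one measured step that bears on this change is a number 3.1 percentage points lower from compound 1 to compound 2 (within the scatter), which also replaces the group on the saturated chain carbon bound to the amide-type nitrogen and carbonyl carbon and stays within the scatter. No step beyond the scatter is therefore expected here, a number 2.2 percentage points higher from compound 2 to compound 3 (within the scatter). Compound 3 is estimated at 10%, between 2% and 20%.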

Compound 3, a percentage reported as activity, at one dose (the size of the read-out at that dose, not a potency): 12.8%
Estimate against measurement, compound 3: 2.8 percentage points below, within the range that was stated.
By their numbers in this assay, from the lowest: compounds 2, 1 and 3 (each within the scatter of the next).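

Isobutyl on the saturated chain carbon bound to an amide-type nitrogen and a carbonyl carbon carries no ester and no aromatic ring, yet the read-out stays within the scatter of both earlier compounds, with a number 5 percentage points higher from compound 2 to compound 3 (within the scatter) and a number 1.9 percentage points higher from compound 1 to compound 3 (within the scatter). Neither benzyloxycarbonyl nor the hydroxyl of 1-hydroxyethyl is therefore required at this position for a read-out of this size at the one dose given. No data on the cause of these numbers are available.

Going by these compounds, a free carboxylic acid, a primary amine or a longer chain such as n-hexyl at this place remains open. Also open, on these data alone, is whether any group at this position moves the number beyond the scatter.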